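Swapping fluoro for methyl on a weak benzyl compound

The compounds below may be only part of what the source reports. "The series", "measured", "known", "first", "only" and "open" are said of these compounds alone.

Compound 1 (`Cc1cc(Nc2cc(-c3ccccc3)[nH]n2)n2nc(SCCCc3ccccc3)nc2n1`) gives 5030 nM
Compound 2 (`Cc1cc(Nc2ccn(Cc3ccc(F)cc3)n2)n2nc(SCc3ccc(Br)cc3)nc2n1`) gives 19400 nM

In a functional assay on PC-9 cells (Homo sapiens) for inhibition, read by MTT assay, with a stated time of 72 h (on this read-out higher numbers stand for weaker inhibition and lower numbers for stronger inhibition), compound 2 has the higher of the two numbers (19400 nM), and its gap to compound 1 (5030 nM) lies beyond the scatter. Among the measured compounds shown here, these two compounds differ in more than one place, so the data hold no single-change step to lean on.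

Compound 3 (`Cc1ccc(Cn2ccc(Nc3cc(C)nc4nc(SCc5ccc(Br)cc5)nn34)n2)cc1`) is still unmeasured and departs from compound 2 at one point, 4-fluorobenzyl to 4-methylbenzyl: methyl in place of fluoro on an aromatic carbon (methyl in place of fluoro on an aromatic carbon, para to a large group). Since the two groups are the same size by heavy-atom count and nothing measured tests this exchange, only a small shift is expected, within the scatter and slightly downward if anything. The expected change is a 1.3-fold lower number from compound 2 to compound 3 (0.11 log units; within the scatter) in this assay for now. For compound 3 the estimated value is 15000 nM, with an expected range from 6000 nM to 40000 nM in the same read-out.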

Compound 3, half-maximal inhibitory concentration: > 50000 nM
Compound 3 ended at the assay's limit (the forecaster's own chance of this, stated with the estimate: 15%); at least 3.3-fold (0.52 log units) between middle value and limit.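

In this assay compound 3 gives > 50000 nM, which is a limit of the assay and not a number. Fluoro and methyl each count one heavy atom and neither adds a hydrogen-bond donor or acceptor, yet this exchange is not neutral here: the result is an at least 2.5-fold higher number from compound 2 to compound 3 (0.41 log units; beyond the scatter), the only single-change step in the set. The aromatic carbon para to a large group therefore responds to this exchange, although the full size of the step cannot be read: the limit of > 50000 nM in this assay, at which 1 of the 3 values shown sits.

The compounds shown leave open whether the loss is specific to methyl, since chloro, methoxy and an amine do not appear at this place among them. Among the compounds shown here, they also do not show whether the same exchange would have a similar effect on a compound with a different group on the sulfur, such as the one in compound 1.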